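Working notes: pendant aryl exchange from compound 3 to compound 4

A few compounds are considered here, and "the series" means these few. Any claim that something is new, unique, unknown or untested is made for them only; others in the source may bear on it.

Measured so far in an assay for inhibition of Catechol O-methyltransferase (Rattus norvegicus), read by fluorescence and spectrophotometry; on this read-out lower numbers stand for stronger inhibition and higher numbers for weaker inhibition:
- compound 1 `N#Cc1ccc(/C=C/C(=O)c2cc(O)c(O)c([N+](=O)[O-])c2)cc1` gives 180 nM
- compound 2 `O=C(/C=C/c1cccs1)c1cc(O)c(O)c([N+](=O)[O-])c1` gives 190 nM
- compound 3 `CC(=O)N1N=C(c2cc(O)c(O)c([N+](=O)[O-])c2)CC1c1ccc(C#N)cc1` gives 48 nM

Compound 3 holds the lowest of the three numbers. Its nearest neighbour is compound 1, whose number sits higher by a margin beyond the usual scatter; compound 2 lies slightly further out, also beyond the scatter. No pair among these three compounds differs in only one place, so no single-point step has yet been measured in this assay.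

Compound 4 `CC(=O)N1N=C(c2cc(O)c(O)c([N+](=O)[O-])c2)CC1c1cccc(O)c1` is the next compound and has not been measured. Its difference from compound 3 is 3-hydroxyphenyl in place of 4-cyanophenyl on a saturated ring carbon. The remainder of the molecule, including the shared core and the acetyl group on the five-membered ring, is unchanged. Among the measured compounds shown here, no measured pair isolates the pendant aryl group, so the direction of the step cannot be read from the series. In the absence of such a comparison the expected step is small, within or close to the scatter, with a slight lean toward a higher number. Compound 4 is therefore estimated at 70 nM, with an expected range from 25 nM to 200 nM. This estimate corresponds to an expected step of a 1.5-fold higher number from compound 3 to compound 4 (0.16 log units; within the scatter) in this assay.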

Compound 4, half-maximal inhibitory concentration: 75 nM
Compound 4: the middle estimate sits 1.1-fold (0.03 log units) below what was measured; the range from low to high includes it.
By their numbers in this assay, from the lowest: compounds 3 and 4 (each within the scatter of the next); then compounds 1 and 2 (each within the scatter of the next).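

In this assay, among the compounds shown here, the exchange of 4-cyanophenyl for 3-hydroxyphenyl on the saturated ring carbon gives a 1.6-fold higher number from compound 3 to compound 4 (0.19 log units; within the scatter), the first single-place step and the first direct comparison of two pendant aryl groups at this position. The 3-hydroxyphenyl group carries a hydrogen-bond donor that 4-cyanophenyl lacks, yet the two values lie within the scatter of each other, so this carbon accepts either aryl group without a separable difference on this read-out. The data shown offer no independent measurement that could account for this outcome.

The exchange alters both the identity of the substituent on the phenyl ring and its place on that ring, so the compounds shown leave the contribution of each unresolved. Also open, as far as these compounds go, is how an unsubstituted phenyl, or a phenyl bearing an amine or a carboxylic acid, would read at this carbon, and whether the acetyl group on the five-membered ring contributes to the values of compound 3 and compound 4.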